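From thiophene to methylsulfonylphenyl: an expected gain in half-life

The source may report more compounds than this note shows. Statements on the series, on what has been measured and on what is new or still open speak of the compounds shown alone.

Compound 1, `N#Cc1ccc(F)cc1Cn1c(N2CCC[C@@H](N)C2)nc2c(-c3cccs3)c[nH]c2c1=O`, is the starting point. In an ADME assay on microsomes from liver (Homo sapiens) for metabolic stability, read by LC-MS, tested at 1 mM (a lower number here means that the compound disappears faster, a higher number that the compound lasts longer), compound 1 gives 0.585 h, the lowest of the two plain numbers available. Compound 2, `N#Cc1ccc(F)cc1Cn1c(N2CCC[C@@H](N)C2)nc2c(-c3ccc(F)cc3)c[nH]c2c1=O`, gives 3.01 h in this assay. Compound 3, `N#Cc1ccc(F)cc1Cn1c(N2CCC[C@@H](N)C2)nc2c(-c3ccc(S(N)(=O)=O)cc3)c[nH]c2c1=O`, reaches > 3.33 h in this assay, and that reading is a limit of the assay rather than a number. The unmeasured compound 4, `CS(=O)(=O)c1cccc(-c2c[nH]c3c(=O)n(Cc4cc(F)ccc4C#N)c(N4CCC[C@@H](N)C4)nc23)c1`, differs from compound 1 in one place: 3-(methylsulfonyl)phenyl in place of thiophen-2-yl on an aromatic carbon. Two measured steps, each also swapping thiophen-2-yl for a substituted phenyl, bear on this change: a 5.1-fold higher number from compound 1 to compound 2 (0.71 log units; beyond the scatter) and an at least 5.6-fold higher number from compound 1 to compound 3 (0.75 log units; beyond the scatter). Both steps run upward by a modest amount, so a rise of similar size in this assay is expected for compound 4, meaning a 4.3-fold higher number from compound 1 to compound 4 (0.63 log units; beyond the scatter). Compound 4 is therefore estimated at 2.5 h in this assay, within a range from 1.2 h to 5 h.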

Compound 4, half-life: > 3.33 h
Compound 4 was reported as a limit (the forecaster's own chance of this, stated with the estimate: 35%); at least 1.3-fold (0.12 log units) between middle value and limit.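

In this assay, a third phenyl group in place of thiophen-2-yl again lasts longer, this time with its substituent in a different place on the ring, as 3-(methylsulfonyl)phenyl: the result is an at least 5.6-fold higher number from compound 1 to compound 4 (0.75 log units; beyond the scatter). Against 4-fluorophenyl the result is an at least 1.1-fold higher number from compound 2 to compound 4 (0.04 log units; that floor lies within the scatter), so no order can be claimed for this pair, and the step between compound 3 and compound 4 cannot be read. How long compound 4 truly lasts remains unknown, because its reading is a limit of the assay: the limit of > 3.33 h in this assay, at which 2 of the 4 values shown sit.

Open, from the compounds shown here alone, is whether a plain phenyl ring with no substituent would give the same rise as these substituted rings. Also open, going by these compounds, is how a carboxylic acid or an amine in place of the methylsulfonyl group would behave on this ring.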